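Swapping a Hydroxyethylamino Group for a Carboxyphenyl Ring

This account rests on a few compounds, and the source may have more. Where it says the series, first, only, none or still open, it means among the compounds named here.

Of the compounds shown here, two from one series have been tested in an assay on HEK293 cells for displacement of a labelled ligand from adenosine receptor A1 (Homo sapiens), with a stated time of 90 min, tested at 1 uM; a higher number here means more inhibition at the concentration tested (going by the name of the read-out), a lower number less inhibition. Compound 1, `CCCn1c(-c2cccc(C(F)(F)F)c2)nc2nc(C3CCCC3)[nH]c2c1=O`, gives 100% there. Compound 2, `CCCn1c(NCCO)nc2nc(C3CCCC3)[nH]c2c1=O`, gives 36% in this assay, the lower of the two numbers, and it sits apart from compound 1 by a gap beyond the usual scatter. Compound 3, `CCCn1c(-c2cccc(C(=O)O)c2)nc2nc(C3CCCC3)[nH]c2c1=O`, has not yet been measured. It differs from compound 2 in one place: 3-carboxyphenyl in place of (2-hydroxyethyl)amino on an aromatic carbon. Compound 1, like compound 3, carries a phenyl ring on the shared core, though one bearing a trifluoromethyl group rather than a carboxylic acid, so compound 3 resembles compound 1 more closely than compound 2 does. Since compound 1 reaches 100% while compound 2 gives 36%, a sizeable rise is expected from the step of a number 29 percentage points higher from compound 2 to compound 3 (beyond the scatter). Compound 3 is expected to give about 65%, within a range from 30% to 95%.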

Compound 3, a percentage reported as inhibition, at one concentration (the size of the read-out at that concentration, not a potency): "not active" (no number reported)
Compound 3 has no reported number here, and the estimate cannot be compared.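

Going by these compounds alone, compound 3 is reported only as "not active", without a number, so no step from compound 2 to compound 3 can be read. Going by these compounds, how large any difference between these two compounds is in this assay stays open. Nothing shown here offers an explanation for this result.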